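Shortening a Side Chain on a Weak Thiazolone Inhibitor

This account rests on a few compounds, and the source may have more. Where it says the series, first, only, none or still open, it means among the compounds named here.

Measured compounds:
- compound 1, `CCCC1(C)SC(NCC2CCCCC2)=NC1=O`, which in an assay on HEK293 cells for binding affinity to 11-beta-hydroxysteroid dehydrogenase type 2 (Homo sapiens), read by scintillation proximity assay (a lower number here means a stronger inhibitor, a higher number a weaker inhibitor), gives "not determined" (no result reported).
- compound 2, `CCCC1(C)SC(NC2CCCCCC2)=NC1=O`, which in this assay gives > 10000 nM.

Compound 2 stands at the limit of this assay rather than at a measured number. Among the measured compounds shown here, that situation is described by the limit of > 10000 nM in this assay, at which 1 of the 2 values shown sits, and it means only that compound 2 is a weak inhibitor, not how weak. For the measured compounds named here, compound 1 carries no number at all, so no measured step exists between the two, and nothing is known about how much a single change moves the read-out here.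

Compound 3, `CCC1(C)SC(NC2CCCCCC2)=NC1=O`, is the unmeasured compound. It differs from compound 2 by hydrogen in place of methyl on a saturated chain carbon, two bonds along the chain from a saturated ring carbon, so the propyl becomes an ethyl on the carbon next to the carbonyl-bearing ring.

Because compound 2 already sits at the limit of this assay, shown by the limit of > 10000 nM in this assay, at which 1 of the 2 values shown sits, the step is expected to be small, with no direction resolvable beyond the scatter; the expected change is a step that the limit leaves unreadable from compound 2 to compound 3. For compound 3 the expected value is 20000 nM, with a range from 5000 nM to 80000 nM, and most likely the assay would again report only a limit.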

Compound 3, half-maximal inhibitory concentration: > 10000 nM
Compound 3 gave a limit, no number; the forecaster's own chance of this, stated with the estimate: 85%; the middle value does not contradict the limit.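

In this assay compound 3 gives > 10000 nM, which is a limit and not a number. No step from compound 2 to compound 3 can be read, because both compounds stand at a limit: the limit of > 10000 nM in this assay, at which 2 of the 3 values shown sit.

The compounds shown leave open how weak compound 2 and compound 3 really are, and whether propyl to ethyl changes inhibition at all.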